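This account rests on a few compounds, and the source may have more. Where it says the series, first, only, none or still open, it means among the compounds named here.

Among the measured compounds shown here, in a functional assay on K562 cells (Homo sapiens) for inhibition, read by sulforhodamine B assay, with a stated time of 48 h, tested at 10 uM (a higher number here means more inhibition of growth at the concentration tested, a lower number less inhibition of growth), compound 1 (`COc1ccc(-c2nc3sc(-c4ccccc4)cn3n2)cc1`) gives 76% and stands highest of the two numbers so far, while compound 2 (`COc1cc(-c2nc3sc(-c4ccccc4)cn3n2)cc(OC)c1OC`) gives 39% in the same test. The gap between these two compounds lies beyond the scatter. Compound 3 (`COc1ccc(-c2nc3sc(-c4ccc(Cl)cc4)cn3n2)cc1`) keeps the core of compound 1 with one change (chloro in place of hydrogen on an aromatic carbon): chloro in place of hydrogen on an aromatic carbon, so phenyl becomes 4-chlorophenyl. For the measured compounds named here, no measured pair shows this change, so in this assay a small downward step, perhaps none beyond the scatter, is expected (a number 6 percentage points lower from compound 1 to compound 3 (within the scatter)). For compound 3 the estimated value is 70% within an expected range (45% to 92%).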

Compound 3, percent growth inhibition at one concentration: 38.5%
Compound 3: middle estimate off by 31.5 percentage points, on the high side; measured number outside the range, below it.
By their numbers in this assay, from the lowest: compounds 3 and 2 (each within the scatter of the next); then compound 1.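

In this assay, swapping phenyl for 4-chlorophenyl adds a single chlorine atom yet gives a number 37.5 percentage points lower from compound 1 to compound 3 (beyond the scatter), so this position on the ring is sensitive to substitution. Compounds 1 and 2 could not show this, as they carry the same phenyl and differ only elsewhere. Nothing available here accounts for the drop. Going by these compounds, whether a fluoro, a methyl or an amine at this position would keep the growth inhibition of compound 1 remains open, as does whether chloro at another position on the ring would lower it as well.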